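A few compounds are considered here, and "the series" means these few. Any claim that something is new, unique, unknown or untested is made for them only; others in the source may bear on it.

Of the compounds shown here, three sharing one core have been measured in a functional assay on cardiac atrium for agonist activity at histamine H2 receptor (Cavia porcellus); a lower number here means a less potent compound, a higher number a more potent compound, by a factor of ten per unit of this negative logarithm. Compound 1, `N=C(NCCCc1c[nH]cn1)NCCC(c1ccccc1)c1ccccn1`, gives 7.39. Compound 2, `N=C(NCCCc1c[nH]cn1)NCCC(c1ccc(Cl)cc1)c1ccccn1`, gives 7.84, and compound 3, `N=C(NCCCc1c[nH]cn1)NCCC(c1cccc(F)c1)c1ccccn1`, gives 7.88. Compound 1 therefore stands lowest of the three, with compound 2 nearest and compound 3 furthest from it.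

The two steps away from compound 1 are alike in kind and size: a number 0.45 log units higher from compound 1 to compound 2 (beyond the scatter) and a number 0.49 log units higher from compound 1 to compound 3 (beyond the scatter). Between the two halogenated compounds the numbers barely move, a number 0.04 log units higher from compound 2 to compound 3 (within the scatter).

Compound 4, `N=C(NCCCc1c[nH]cn1)NCCC(c1ccccc1)c1ccc(Cl)c(Cl)c1`, differs from compound 1 in one place: 3,4-dichlorophenyl in place of pyridin-2-yl on a saturated chain carbon bound to an aromatic carbon and a saturated chain carbon. This change has two faces. Putting chlorine on an aromatic ring resembles the steps to compound 2 and compound 3, which raised the number modestly. Yet the ring that leaves is a pyridine, and no measured step tells what removing that ring does; the comparison rests on the halogen steps alone.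

On that basis a modest rise is expected, a number 0.21 log units higher from compound 1 to compound 4 (within the scatter), with wide uncertainty. The estimate for compound 4 in this assay is 7.6, between 6.8 and 8.3.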

Compound 4, negative logarithm of the half-maximal effective concentration: 7.46
The estimate for compound 4 lay 0.14 log units above the measured number, and the stated range covers the measured number.
By their numbers in this assay, from the lowest: compounds 1 and 4 (each within the scatter of the next); then compounds 2 and 3 (each within the scatter of the next).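

In this assay, the place on a saturated chain carbon bound to an aromatic carbon and a saturated chain carbon accepts an exchange of whole rings with no clear effect: a number 0.07 log units higher from compound 1 to compound 4 (within the scatter). Among the compounds shown here, the pyridin-2-yl ring, with its ring nitrogen, can therefore give way to the all-carbon 3,4-dichlorophenyl ring without the number moving beyond the scatter, something the earlier steps could not show, since all of those compounds kept the pyridine. This single step removes the pyridine and brings in the chlorines at once, so any separate contributions cannot be told apart, and nothing available explains the result.

A plain phenyl in place of pyridin-2-yl would show what the ring exchange does without chlorine, and so whether the chlorines matter on this ring at all. A methoxy group or an amine on this ring would show whether the tolerance seen here extends beyond halogens.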